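Replacing One Aromatic Ring on a Shared Core

This account rests on a few compounds, and the source may have more. Where it says the series, first, only, none or still open, it means among the compounds named here.

Of the compounds shown here, three have so far been tested in a functional assay on GBM1 cells (Homo sapiens) for antiproliferative activity, read by WST assay, with a stated time of 72 h; on this read-out higher numbers stand for weaker inhibition and lower numbers for stronger inhibition. Compound 1 `O=C(Nc1ccccc1F)Nc1cc2ncncc2cc1OCc1cccc(F)c1` gives 8000 nM. Compound 2 `O=C(Nc1cccc(Cl)c1)Nc1cc2ncncc2cc1OCc1ccccc1` gives 5700 nM, the second highest of the three numbers; its nearest neighbour is compound 1, within the scatter, and its furthest is compound 3 `O=C(Nc1cccc(Cl)c1)Nc1cc2ncncc2cc1OCc1ccccc1Cl`, which gives 2600 nM. For the measured compounds named here, the only single change measured so far is a 2.2-fold lower number from compound 2 to compound 3 (0.34 log units; beyond the scatter), a change elsewhere in the molecule rather than on the amide-type nitrogen. Compound 4 `O=C(Nc1ccccc1F)Nc1cc2ncncc2cc1OCc1ccccc1` has not yet been measured. It differs from compound 2 by 2-fluorophenyl in place of 3-chlorophenyl on an amide-type nitrogen. Going by the values given here, no measured step covers this change, so the expectation rests on the numbers alone: compound 1 carries the same 2-fluorophenyl group and its number lies within the scatter of the number for compound 2. Compound 4 is therefore expected to show a 1.6-fold higher number from compound 2 to compound 4 (0.20 log units; within the scatter), nothing beyond the scatter. Compound 4 is estimated at 9000 nM, with a range from 4000 nM to 20000 nM.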

Compound 4, half-maximal inhibitory concentration: 6100 nM
For compound 4 the middle estimate is 1.5-fold (0.17 log units) above the measured one; the measured number falls inside the stated range.
By their numbers in this assay, from the lowest: compound 3; then compounds 2, 4 and 1 (each within the scatter of the next).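

In this assay, the amide-type nitrogen has now been changed directly, and 2-fluorophenyl in place of 3-chlorophenyl gives a 1.1-fold higher number from compound 2 to compound 4 (0.03 log units; within the scatter), so these two groups cannot be told apart here. Hydrogen in place of fluoro on an aromatic carbon gives a 1.3-fold lower number from compound 1 to compound 4 (0.12 log units; within the scatter), which also stays within the scatter, so this fluoro makes no clear difference in the one pair that tests it. No data at hand explain either result.

Going by these compounds, only these two substituted phenyl groups are compared on this nitrogen, so it remains open whether a pyridine ring, a cyclohexyl ring or a simple methyl there would change the number. On these data alone, it is also open whether the chloro that separates compound 3 from compound 2 would have a similar effect in a compound carrying 2-fluorophenyl.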